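The compounds below may be only part of what the source reports. "The series", "measured", "known", "first", "only" and "open" are said of these compounds alone.

Measured in a functional assay on HCT-116 cells (Homo sapiens) for cytotoxicity, read by MTT assay, with a stated time of 72 h; a lower number here means a stronger inhibitor, a higher number a weaker inhibitor:
- compound 1 `O=C1c2c[n+]([O-])c3ccccc3c2C(=O)c2c1c1ccccc1n2Cc1cn([C@@H]2C[C@H](O)[C@@H](CO)O2)nn1`: 50 nM
- compound 2 `O=C1c2c[n+]([O-])c3ccccc3c2C(=O)c2c1c1ccccc1n2Cc1cn([C@H]2C[C@H](O)[C@@H](CO)O2)nn1`: 120 nM

Among the measured compounds shown here, compound 2 holds the higher of the two numbers, and compound 1 is its only neighbour. For the measured compounds named here, the single measured step is a 2.4-fold higher number from compound 1 to compound 2 (0.38 log units; beyond the scatter), and what separates the pair is the fact that compounds 1 and 2 differ only in the configuration as drawn. That step shows that the number moves when only the group on the aromatic nitrogen changes its drawn configuration.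

The next step leads to compound 3 `O=C1c2c[n+]([O-])c3ccccc3c2C(=O)c2c1c1ccccc1n2Cc1cn([C@@H]2O[C@H](CO)[C@@H](O)[C@H](O)[C@H]2O)nn1`, where 3,4,5-trihydroxy-6-(hydroxymethyl)oxan-2-yl stands in place of 4-hydroxy-5-(hydroxymethyl)oxolan-2-yl on an aromatic nitrogen 3,4,5-trihydroxy-6-(hydroxymethyl)oxan-2-yl in place of 4-hydroxy-5-(hydroxymethyl)oxolan-2-yl on an aromatic nitrogen and the shared core is kept. Going by the values given here, no measured step covers a change of ring size or of substituent count, so the evidence here is thin. Among the compounds with values here, with a 2.4-fold higher number from compound 1 to compound 2 (0.38 log units; beyond the scatter) as the only guide to scale, a modest step is expected in this assay, probably towards a higher number, though no measurement fixes the direction. The expected step is a 2.1-fold higher number from compound 2 to compound 3 (0.32 log units; beyond the scatter). The estimate for compound 3 is 250 nM, with an expected range of 70 nM to 900 nM.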

Compound 3, half-maximal inhibitory concentration: 130 nM
The estimate for compound 3 lay 1.9-fold (0.28 log units) above the measured number, and the stated range covers the measured number.
By their numbers in this assay, from the lowest: compound 1; then compounds 2 and 3 (each within the scatter of the next).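

On the aromatic nitrogen of the five-membered aromatic ring with 3 nitrogen, the change from 4-hydroxy-5-(hydroxymethyl)oxolan-2-yl to 3,4,5-trihydroxy-6-(hydroxymethyl)oxan-2-yl gives in this assay a step within the scatter (a 1.1-fold higher number from compound 2 to compound 3 (0.03 log units; within the scatter)), so this position accepts the six-membered ring with its added hydroxyl groups and stereocentres without a measurable shift against compound 2. Read against the other five-membered compound, the same replacement gives a step beyond the scatter (a 2.6-fold higher number from compound 1 to compound 3 (0.41 log units; beyond the scatter)), so the size of the change depends on which drawn form of the five-membered group serves as the reference. Those two references are separated by one thing only: the fact that compounds 1 and 2 differ only in the configuration as drawn.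

The compounds shown leave open how an amine or a carboxylic acid at this position, in place of the hydroxylated rings, would read in this assay. They also leave open whether a change of drawn configuration within 3,4,5-trihydroxy-6-(hydroxymethyl)oxan-2-yl moves the number as it does in the five-membered pair.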